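The source may report more compounds than this note shows. Statements on the series, on what has been measured and on what is new or still open speak of the compounds shown alone.

Compound 1 `Cc1nc2ccccc2n1CCCCOc1ccccc1` in an ADME assay on Vero cells (Chlorocebus sabaeus) for cytotoxicity, read by luminescence, with a stated time of 2 days (on this read-out higher numbers stand for lower toxicity in this test and lower numbers for higher toxicity in this test), gives a limit of the test, > 50 uM.
Compound 2 `CCc1nc2ccccc2n1CCCCOc1ccccc1C(C)C` in this assay gives 19 uM.
Compound 3 `CCc1nc2ccccc2n1CCCCOCc1ccccc1` in this assay gives 32 uM.

Among the two plain numbers, compound 3 stands at the higher one, with compound 2 close by and within the usual scatter, so no order can be read between them. Compound 1 sits at the limit of > 50 uM in this assay, at which 1 of the 3 values shown sits, a boundary rather than a number. Compound 4 `CCc1nc2ccccc2n1CCCCOc1ccc(Cl)cc1F` has not been measured; relative to compound 3 it carries 4-chloro-2-fluorophenyl in place of benzyl on an oxygen on a saturated carbon. For the measured compounds named here, no step between measured compounds is available to guide the size of this change. The step is expected to be small, probably within the scatter, with the number for compound 4 estimated to move by a 1.5-fold lower number from compound 3 to compound 4 (0.16 log units; within the scatter). Compound 4 is expected to give about 22 uM, between 8 uM and 50 uM.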

Compound 4, half-maximal toxic concentration: 5.7 uM
The estimate for compound 4 lay 3.9-fold (0.59 log units) above the measured number; the whole stated range lies above it.
By their numbers in this assay, from the lowest: compound 4; then compounds 2 and 3 (each within the scatter of the next). At a limit, above all of these: compound 1.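

Swapping benzyl for 4-chloro-2-fluorophenyl on an oxygen on a saturated carbon is not a neutral change: in this assay it gives a 5.6-fold lower number from compound 3 to compound 4 (0.75 log units; beyond the scatter), so toxicity in this test is higher after the swap. The earlier compounds shown here offered no step at all, so this is the only measured size for a change at this position. Nothing measured here accounts for the step.

From the compounds shown here alone, it remains open whether the chlorine or the fluorine alone carries this step, and what an amine or a carboxylic acid in that place would give.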